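Trading a Hydroxyethyl Amide for an Azetidine Amide

The source may hold more compounds than are shown below. What is called first, only, known or untested is meant among the compounds shown, and "the series" means these compounds.

Of the compounds shown here, three built on one shared core have been tested in a functional assay on the whole organism with Mus musculus as the target, at a dose of 100 mg/kg by the intraperitoneal route; on this read-out lower numbers stand for less inhibition and higher numbers for more inhibition at the one dose given (going by the name of the read-out). Compound 1 `CNC(=O)/C=C1\CCc2cc(F)c(F)cc21` gives 100%, compound 2 `O=C(/C=C1\CCc2cc(Cl)ccc21)NC1CC1` gives 17%, and compound 3 `O=C(/C=C1\CCc2ccc(F)cc21)NCCO` gives 50%. Compound 3 therefore stands second highest of the three: compound 2 lies nearest, a number lower beyond the scatter, and compound 1 lies furthest, a number higher beyond the scatter. Compound 4 `O=C(/C=C1\CCc2ccc(F)cc21)N1CCC1` differs from compound 3 in one place: azetidin-1-yl in place of (2-hydroxyethyl)amino on a carbonyl carbon. Among the measured compounds shown here, no two measured compounds differ in only one place, so no measured step shows what such a change does in this assay. The expected step is a number 15 percentage points lower from compound 3 to compound 4 (beyond the scatter), a fall of modest size, within or just beyond the scatter. Compound 4 is estimated at 35%, with a range from 5% to 70%.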

Compound 4, a percentage reported as inhibition, in the whole organism at one dose (the size of the read-out at that dose, not a potency): 33%
Beside the measured number, compound 4's estimate is 2 percentage points above it, within the range that was stated.
By their numbers in this assay, from the lowest: compound 2; then compound 4; then compound 3; then compound 1.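

Among the compounds shown here, this pair is the first measured single change at this position: in this assay, azetidin-1-yl in place of (2-hydroxyethyl)amino on the carbonyl carbon gives a number 17 percentage points lower from compound 3 to compound 4 (beyond the scatter). The two groups have the same heavy-atom count, but the change closes a four-membered ring and removes the oxygen and the hydrogen-bond donors of the open chain. Nothing measured here explains the fall. Which of these differences matters remains open: an azetidine carrying a hydroxyl would keep the ring and the oxygen, while an ethylamino group would keep the open chain without the oxygen.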